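A few compounds are considered here, and "the series" means these few. Any claim that something is new, unique, unknown or untested is made for them only; others in the source may bear on it.

Of the compounds shown here, two have been measured in an assay on CHO cells with Alpha-2B adrenergic receptor (Homo sapiens) as the target; a lower number here means a smaller maximal response, a higher number a larger maximal response. Compound 1 `CCOc1ccccc1OC(C)C1=NCCN1` gives 0.5. Compound 2 `CC(Oc1ccccc1S(C)(=O)=O)C1=NCCN1` gives 0.45. Within the data shown here, the one change between them, methylsulfonyl in place of ethoxy on an aromatic carbon, gave a number 0.050 lower from compound 1 to compound 2 (within the scatter). Among the two numbers measured so far compound 2 stands lowest, but the nearest number, that of compound 1, lies within the scatter of it, so the two cannot be told apart.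

Compound 3 `CCc1ccccc1OC(C)C1=NCCN1` has not yet been measured. It differs from compound 2 in one place: ethyl in place of methylsulfonyl on an aromatic carbon. Among the measured compounds shown here, the only measured step that bears on this change is the one from compound 1 to compound 2, which stayed within the scatter. A change at the same place is therefore expected to give a number 0.050 higher from compound 2 to compound 3 (within the scatter), no shift beyond the scatter. Compound 3 is expected to give 0.5, within a range from 0.35 to 0.65.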

Compound 3, intrinsic activity: the largest response reached, as a fraction of the reference agonist's: 0.5
Compound 3: the middle estimate sits on the measured number at the digits printed; the measured number falls inside the stated range.
By their numbers in this assay, from the lowest: compounds 2, 1 and 3 (each within the scatter of the next).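

In this assay, ethyl in place of methylsulfonyl on this aromatic carbon gave a number 0.050 higher from compound 2 to compound 3 (within the scatter) and ethyl in place of ethoxy gave no change at the digits printed from compound 1 to compound 3 (within the scatter), so all three groups now tested at this place give maximal responses that cannot be told apart. The earlier pair covered only ethoxy and methylsulfonyl, whereas ethyl is smaller than methylsulfonyl by count of heavy atoms and has no hydrogen-bond acceptors, and even this swap stays within the scatter. Nothing at hand explains why these groups cannot be told apart here.

The compounds shown leave open whether an amine, a carboxylic acid or a longer chain at this place would move the maximal response beyond the scatter. They also leave open whether these three groups would still match on another carbon of the aromatic ring.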